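Swapping methyl for (ethoxymethyl)carbonyl on an aromatic oxygen

The compounds below may be only part of what the source reports. "The series", "measured", "known", "first", "only" and "open" are said of these compounds alone.

- Compound 1 `COc1ccc2c(c1)cc(-c1cc(OC)c(OC)c(OC)c1)n2Cc1ccc(O)cc1` gives 17300 nM
- Compound 2 `COc1ccc(Cn2c(-c3cc(OC)c(OC)c(OC)c3)cc3cc(OC)ccc32)cc1` gives > 30000 nM (a limit, not a number)

Both compounds were tested in a functional assay on MDA-MB-231 cells (Homo sapiens) for cytotoxicity, read by MTT assay, with a stated time of 24 h; a lower number here means a stronger inhibitor, a higher number a weaker inhibitor. Compound 2 has no exact value there, and its > 30000 nM is only a limit. Among the measured compounds shown here, it is the one compound resting on (the limit of > 30000 nM in this assay, at which 1 of the 2 values shown sits).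

Compound 3 `CCOCC(=O)Oc1ccc(Cn2c(-c3cc(OC)c(OC)c(OC)c3)cc3cc(OC)ccc32)cc1` carries (ethoxymethyl)carbonyl in place of methyl on an oxygen on an aromatic ring of compound 2, and the counted difference is (ethoxymethyl)carbonyl in place of methyl on an oxygen on an aromatic ring.

For the measured compounds named here, only one measured step touches this oxygen, where methyl replaces hydrogen. That step is an at least 1.7-fold higher number from compound 1 to compound 2 (0.23 log units; that floor lies within the scatter). Going by the values given here, it is a floor rather than a true size, and no measured compound carries a group like the incoming one, so the evidence is thin. The expectation is therefore a small move towards a lower number in this assay, perhaps none beyond the scatter, and compound 3 may again return only a limit.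

The expected change is an at least 1.5-fold lower number from compound 2 to compound 3 (0.19 log units; that floor lies within the scatter).

Compound 3 is estimated at 19000 nM, with an expected range from 6000 nM to 30000 nM.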

Compound 3, half-maximal inhibitory concentration: > 30000 nM
Compound 3 ended at the assay's limit (the forecaster's own chance of this, stated with the estimate: 40%); middle value at least 1.5-fold (0.19 log units) away from the limit.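

In this assay compound 3 gives > 30000 nM, which is a limit and not a number. With (ethoxymethyl)carbonyl in place of hydrogen on this oxygen, the comparison reads an at least 1.7-fold higher number from compound 1 to compound 3 (0.23 log units; that floor lies within the scatter), so the larger group, like the single methyl before it, gives only a floor and no true size. The change from methyl to (ethoxymethyl)carbonyl cannot be read, because compound 2 and compound 3 rest on the same limit: the limit of > 30000 nM in this assay, at which 2 of the 3 values shown sit.

Among the compounds shown here, compound 1, with its free hydrogen on this oxygen, remains the only compound here with an exact value, at 17300 nM, so it is still unknown whether any group on this oxygen can give a lower number in this assay. An ethyl group or a chain ending in an amine or a carboxylic acid might show this, and such a compound would need an exact value to make a step at this position readable.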